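Sulfonamide aryl swap: from compound 3 to compound 4

A few compounds are considered here, and "the series" means these few. Any claim that something is new, unique, unknown or untested is made for them only; others in the source may bear on it.

Compound 1 `CCc1ccc(NS(=O)(=O)c2ccc(N3CCNC3=O)cc2)cc1` gives 660 nM in a functional assay on HT-29 cells (Homo sapiens) for antiproliferative activity, read by sulforhodamine B assay, with a stated time of 48 h; a higher number here means a weaker inhibitor, a lower number a stronger inhibitor.
Compound 2 `O=C1NCCN1c1ccc(S(=O)(=O)Nc2ccc(F)c(F)c2)cc1` gives 350 nM in this assay.
Compound 3 `O=C1NCCN1c1ccc(S(=O)(=O)Nc2ccc(I)cc2)cc1` gives 650 nM in this assay.

Compound 3 stands second highest of the three numbers, nearest compound 1 by a 1.0-fold lower number from compound 1 to compound 3 (0.01 log units; within the scatter) and furthest from compound 2 by a 1.9-fold higher number from compound 2 to compound 3 (0.27 log units; within the scatter); all three values sit within the scatter of one another. Compound 4 `Cc1cccc(NS(=O)(=O)c2ccc(N3CCNC3=O)cc2)c1C` is unmeasured. The change: 2,3-dimethylphenyl in place of 4-iodophenyl on a sulfonamide nitrogen. The steps bearing on it are those that also exchange the aryl on the sulfonamide nitrogen, a 1.9-fold lower number from compound 1 to compound 2 (0.28 log units; within the scatter) and a 1.9-fold higher number from compound 2 to compound 3 (0.27 log units; within the scatter), neither beyond the scatter. No step larger than the scatter is therefore expected in this assay, in either direction. Compound 4 is expected to give 600 nM, within 250 nM to 1500 nM, a step of a 1.1-fold lower number from compound 3 to compound 4 (0.03 log units; within the scatter).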

Compound 4, half-maximal inhibitory concentration: 190 nM
For compound 4 the middle estimate is 3.2-fold (0.50 log units) above the measured one; the measured number lies below the stated range.
By their numbers in this assay, from the lowest: compounds 4, 2, 3 and 1 (each within the scatter of the next, the first and the last beyond it).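

In this assay, exchanging the aryl on the sulfonamide nitrogen now gives steps beyond the scatter (a 3.4-fold lower number from compound 3 to compound 4 (0.53 log units; beyond the scatter); a 3.5-fold lower number from compound 1 to compound 4 (0.54 log units; beyond the scatter)), which no earlier exchange there did. The step from 3,4-difluorophenyl to 2,3-dimethylphenyl stays within the scatter (a 1.8-fold lower number from compound 2 to compound 4 (0.27 log units; within the scatter)), so the change separates compound 4 from only two of the three earlier compounds. No measurement available here bears on the reason for these steps.

As far as these compounds go, whether both methyl groups are needed, or one alone would do, stays open. So does the effect of an amine or a carboxylic acid on this aryl.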